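The source may hold more compounds than are shown below. What is called first, only, known or untested is meant among the compounds shown, and "the series" means these compounds.

Measured so far:
Compound 1 `Cc1cc(C(=O)Nc2ccccc2)nn1Cc1cc(Cl)ccc1OCc1ccccc1`: "not determined" (no result reported)
Compound 2 `Cc1cc(NC(=O)OC(C)(C)C)nn1Cc1cc(Cl)ccc1OCc1ccccc1`: 42 mL/min/kg

Both entries come from an in vivo ADME assay on the whole organism (blood) for pharmacokinetics, with Rattus norvegicus as the target; on this read-out lower numbers stand for slow clearance and higher numbers for fast clearance. Within the data shown here, no result was reported for compound 1, so compound 2 stands alone, and its 42 mL/min/kg is the only number. With nothing to compare it against, it cannot yet be placed as high or low among related compounds.

The next compound to be tested is compound 3 `Cc1cc(NC(=O)OCC(C)C)nn1Cc1cc(Cl)ccc1OCc1ccccc1`. It differs from compound 2 at a single place: isobutyl in place of tert-butyl on an oxygen next to a carbonyl group. This puts isobutyl in place of tert-butyl on an oxygen next to a carbonyl group, and the two compounds have the same atoms, joined differently.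

Among the measured compounds shown here, no measured pair shows how this assay responds to a change of this kind, so the expectation is loose. With compound 2 at 42 mL/min/kg as the only anchor, a small step is expected, no larger than the usual scatter and leaning slightly towards faster clearance. The estimated step of a 1.2-fold higher number from compound 2 to compound 3 (0.08 log units; within the scatter) reflects that lean. Compound 3 is expected at 50 mL/min/kg, within an estimated range of 25 mL/min/kg to 90 mL/min/kg.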

Compound 3, clearance: 124 mL/min/kg
For compound 3 the middle estimate is 2.5-fold (0.39 log units) below the measured one; the measured number lies above the stated range.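

Swapping tert-butyl for isobutyl on an oxygen next to a carbonyl group gives a 3.0-fold higher number from compound 2 to compound 3 (0.47 log units; beyond the scatter) in this assay and this is the first sign that clearance in this series responds to the group at this position. Among these compounds, the two compounds have the same atoms, joined differently, so the way these atoms are arranged in the group is enough to move the read-out beyond the usual scatter, something that the single number available earlier could not show. Nothing measured here explains why the rearrangement has this effect.

A single pair cannot show whether clearance follows the shape of the chain in general or whether this result belongs only to these two groups, and it cannot show whether the same swap would act alike on another part of the molecule. A straight butyl chain, a longer hexyl chain, a ring such as cyclohexyl or a chain carrying an amine at this position would show how far the effect extends.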